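The compounds below may be only part of what the source reports. "The series", "measured", "known", "first", "only" and "open" are said of these compounds alone.

Measured so far:
Compound 1 `Cc1ccccc1C1(CNC(=O)Nc2c(C(C)C)cccc2C(C)C)CCCC1` — in an assay on microsomes for inhibition of acyl-CoA:cholesterol acyltransferase (Oryctolagus cuniculus) (a lower number here means a stronger inhibitor, a higher number a weaker inhibitor), compound 1 gives 17 nM.
Compound 2 `Cc1cccc(C2(CNC(=O)Nc3c(C(C)C)cccc3C(C)C)CCCC2)c1` — in this assay compound 2 gives 15 nM.

Among the measured compounds shown here, compound 2 holds the lowest of the two numbers measured in this assay, but its only neighbour, compound 1, sits so close that the two cannot be told apart: the step of a 1.1-fold lower number from compound 1 to compound 2 (0.05 log units; within the scatter) lies within the scatter.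

Compound 3 `Cc1ccc(C2(CNC(=O)Nc3c(C(C)C)cccc3C(C)C)CCCC2)cc1` is the next member of the series and is still to be measured. The change from compound 2 to compound 3 is 4-methylphenyl in place of 3-methylphenyl on a saturated ring carbon. For the measured compounds named here, the one measured step that bears on it is the earlier move of the same methyl group around the same aromatic ring, a 1.1-fold lower number from compound 1 to compound 2 (0.05 log units; within the scatter), which produced no change beyond the scatter. With a single relevant step of that size, and nothing else in the set to point in either direction, the expectation for this assay is a step of no meaningful size, a 1.1-fold higher number from compound 2 to compound 3 (0.03 log units; within the scatter), neither clearly up nor clearly down.

Compound 3 is therefore estimated to give about 16 nM in this assay, with a likely range from 7 nM to 40 nM.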

Compound 3, half-maximal inhibitory concentration: 25 nM
Beside the measured number, compound 3's estimate is 1.6-fold (0.19 log units) below it; the range from low to high includes it.
By their numbers in this assay, from the lowest: compounds 2, 1 and 3 (each within the scatter of the next).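

Among the compounds shown here, with 4-methylphenyl on the saturated ring carbon, the methyl group has now been read in all three placements named by 2-methylphenyl, 3-methylphenyl and 4-methylphenyl, where the earlier compounds offered only one comparison. In this assay both new steps stay within the scatter, with a 1.7-fold higher number from compound 2 to compound 3 (0.22 log units; within the scatter) and a 1.5-fold higher number from compound 1 to compound 3 (0.17 log units; within the scatter) leaving compound 1, compound 2 and compound 3 without any order that can be trusted; across these three compounds, moving the methyl group around the aromatic ring gives no change that can be told from repeat variation. No measurement is available that could explain the small differences among the three numbers.

The compounds shown leave open whether a different group on the same aromatic ring, such as a methoxy group, a chlorine atom, an amine or a carboxylic acid, would be accommodated as evenly across these placements as methyl is. They also leave open whether the same insensitivity would hold with a six-membered saturated ring of carbon in place of the five-membered non-aromatic ring that all three share.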